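Trimethoxyphenyl-naphthyl methanes: the swing from aryl to allyloxy

The source may hold more compounds than are shown below. What is called first, only, known or untested is meant among the compounds shown, and "the series" means these compounds.

Measured so far in a functional assay on MCF7 cells (Homo sapiens) for inhibition, read by sulforhodamine B assay, with a stated time of 48 h; on this read-out lower numbers stand for stronger inhibition and higher numbers for weaker inhibition:
compound 1 `COc1ccc(C(c2ccccc2O)c2cccc3ccccc23)c(OC)c1OC` — 16600 nM
compound 2 `COc1ccc(C(c2ccc(OCCO)cc2)c2cccc3ccccc23)c(OC)c1OC` — > 20000 nM
compound 3 `COc1ccc(C(c2ccc(OCC(=O)O)cc2)c2cccc3ccccc23)c(OC)c1OC` — > 20000 nM

Compound 1 gives a numerical value, 16600 nM, in this assay. For compound 2 this assay reports only a limit, > 20000 nM. For compound 3 the same holds: a limit, > 20000 nM. Compound 3 therefore stands at the floor of the series, as the limit of > 20000 nM in this assay, at which 2 of the 3 values shown sit, shows; the steps of an at least 1.2-fold higher number from compound 1 to compound 2 (0.08 log units; that floor lies within the scatter) and an at least 1.2-fold higher number from compound 1 to compound 3 (0.08 log units; that floor lies within the scatter) are both read only as floors, and a step that the two limits leave unreadable from compound 2 to compound 3 stays unreadable.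

Compound 4 `C=CCOC(c1ccc(OC)c(OC)c1OC)c1cccc2ccccc12` is not yet measured. Its change from compound 3 is allyloxy in place of 4-(carboxymethoxy)phenyl on a saturated chain carbon bound to two aromatic carbons. Within the data shown here, none of the measured steps touches an allyloxy group; the two steps from compound 1 only tell that exchanging the 2-hydroxyphenyl at this carbon gave a limit. The step of a number no higher from compound 3 to compound 4 (the limit leaves the size open) is thus expected to be flat, with a fair chance of another limit. Compound 4 is estimated at 20000 nM, within 7000 nM to 60000 nM.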

Compound 4, half-maximal inhibitory concentration: > 20000 nM
Compound 4: no number, only a limit (the forecaster's own chance of this, stated with the estimate: 55%); the middle value lies on the limit itself.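

In this assay compound 4 gives only a limit, > 20000 nM. Among these compounds, the one readable step is an at least 1.2-fold higher number from compound 1 to compound 4 (0.08 log units; that floor lies within the scatter), so a small allyloxy group with no ring, at the saturated chain carbon bound to two aromatic carbons, ends at the same limit as the two aryl replacements of 2-hydroxyphenyl, and a numerical value is not recovered by leaving out the aromatic ring of that substituent. The steps among compound 2, compound 3 and compound 4 cannot be read, and the series now gathers at one ceiling: the limit of > 20000 nM in this assay, at which 3 of the 4 values shown sit.

Only compound 1 gives a number, 16600 nM, so the groups at this carbon cannot be ranked against one another. As far as these compounds go, whether an amine on a short chain at this carbon, or a phenyl ring carrying an amine, would give a measurable value in this assay remains open.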